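This account rests on a few compounds, and the source may have more. Where it says the series, first, only, none or still open, it means among the compounds named here.

Measured compounds:
- Compound 1, `c1cnc2c(c1)CCC[C@@H]2N(CC1CC1)C[C@H]1Cc2c(cccc2N2CCNCC2)CN1`, gives 26.7 nM in a functional assay on CCRF-CEM cells for antagonist activity at C-X-C chemokine receptor type 4 (Homo sapiens), read by calcium flux, with stated times of 25 min and 90 s; on this read-out higher numbers stand for weaker inhibition and lower numbers for stronger inhibition.
- Compound 2, `CC(C)N1CCN(c2cccc3c2C[C@H](CN(C)[C@H]2CCCc4cccnc42)NC3)CC1`, gives 16.9 nM in this assay.

Of the two numbers recorded in this assay, compound 1 has the higher one, but its nearest neighbour, compound 2, sits within the scatter of it, so the two values show no difference that can be trusted. The two compounds also differ in more than one place, so nothing in these data isolates any single change.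

Compound 3, `CCN(C[C@H]1Cc2c(cccc2N2CCNCC2)CN1)[C@H]1CCCc2cccnc21`, has not yet been measured in this assay. It is reached from compound 1 by the change (methyl in place of cyclopropyl on a saturated chain carbon bound to an amine nitrogen), which shortens the substituent on the amine nitrogen while leaving the shared core untouched.

Within the data shown here, no measured pair shows this change on its own. Compound 2, which carries the smallest group on that nitrogen and gives 16.9 nM, suggests that a short group is tolerated. The step of a 1.1-fold higher number from compound 1 to compound 3 (0.05 log units; within the scatter) is therefore expected to stay within the scatter, with no clear direction. Compound 3 is estimated at 30 nM, with a range from 10 nM to 90 nM.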

Compound 3, half-maximal inhibitory concentration: 14.8 nM
Estimate against measurement, compound 3: 2.0-fold (0.31 log units) above, and the stated range covers the measured number.
By their numbers in this assay, from the lowest: compounds 3, 2 and 1 (each within the scatter of the next).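

In this assay, the exchange of methyl for cyclopropyl on a saturated chain carbon bound to an amine nitrogen, which reads as cyclopropylmethyl to ethyl when cut one bond further out, gives a 1.8-fold lower number from compound 1 to compound 3 (0.26 log units; within the scatter). This is the first pair among the compounds shown that isolates the group on this amine nitrogen, and it shows that this read-out does not separate the two groups: losing the three-membered ring leaves no difference that can be trusted. Nothing at hand explains why the two groups read alike.

Among these compounds, this single pair covers only two small carbon groups at one place on the core of compound 1, so it sets no general rule for that place, and it says nothing about how far the insensitivity extends. The compounds shown leave open whether a plain hydrogen on that nitrogen, a longer chain such as butyl, a benzyl group, or a chain ending in an amine or a carboxylic acid would also stay within the scatter of compound 1 or move the number clearly in either direction.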